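The source may hold more compounds than are shown below. What is called first, only, known or untested is meant among the compounds shown, and "the series" means these compounds.

Compound 1, `CC1CCN(c2c(S(=O)(=O)c3ccc(C#N)cc3)cnc3cc(F)ccc23)CC1`: 83%
Compound 2, `Cc1cc(C)cc(S(=O)(=O)c2cnc3cc(F)ccc3c2N2CCC(C)CC2)c1`: 80%
Compound 3, `CC1CCN(c2c(S(=O)(=O)c3ccc(F)cc3)cnc3cc(F)ccc23)CC1`: 74.5%

In an assay on isolated protein for displacement of a labelled ligand from metabotropic glutamate receptor 5 (Homo sapiens), with a stated time of 60 min, tested at 1 uM (on this read-out higher numbers stand for more inhibition at the one concentration tested (going by the name of the read-out) and lower numbers for less inhibition), compound 3 gives the smallest of the three numbers, but the steps of a number 8.5 percentage points lower from compound 1 to compound 3 (within the scatter) and a number 5.5 percentage points lower from compound 2 to compound 3 (within the scatter) both lie within the scatter, so the three compounds cannot be separated on these numbers. Compound 4, `Cc1ccc(S(=O)(=O)c2cnc3cc(F)ccc3c2N2CCC(C)CC2)cc1C`, has not yet been measured. It differs from compound 3 in one place: 3,4-dimethylphenyl in place of 4-fluorophenyl on a sulfonyl sulfur.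

For the measured compounds named here, two measured steps bear on this change, since both swap the aryl group on the sulfonyl sulfur. The step of a number 5.5 percentage points lower from compound 2 to compound 3 (within the scatter) runs in the opposite sense to the change now made, exchanging a dimethylphenyl for the 4-fluorophenyl, and stayed within the scatter. The step of a number 3 percentage points lower from compound 1 to compound 2 (within the scatter) also moved the aryl group on the sulfonyl sulfur and likewise stayed within the scatter. Neither step gives grounds to expect a move beyond the scatter; if anything, reversing the direction of a number 5.5 percentage points lower from compound 2 to compound 3 (within the scatter) points to a number slightly above that of compound 3, so the expected step is a number 5.5 percentage points higher from compound 3 to compound 4 (within the scatter). On that basis compound 4 is estimated to give 80% in this assay, within a range from 70% to 90%.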

Compound 4, a percentage reported as inhibition, at one concentration (the size of the read-out at that concentration, not a potency): 90%
Estimate against measurement, compound 4: 10 percentage points below; low and high end bracket the measured number.
By their numbers in this assay, from the lowest: compounds 3, 2, 1 and 4 (each within the scatter of the next, the first and the last beyond it).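

In this assay, for the compounds shown here, a change of the aryl group on the sulfonyl sulfur now gives a number 15.5 percentage points higher from compound 3 to compound 4 (beyond the scatter) with 3,4-dimethylphenyl in place of 4-fluorophenyl, so the choice of group at this place can move the number beyond the scatter, which none of the earlier steps showed. That reach is limited to this one pair: the other two new steps, a number 10 percentage points higher from compound 2 to compound 4 (within the scatter) and a number 7 percentage points higher from compound 1 to compound 4 (within the scatter) as the swaps of 3,5-dimethylphenyl and of 4-cyanophenyl for 3,4-dimethylphenyl, both lie within the scatter, so compound 4 cannot be separated from either of those two compounds. No measured evidence is at hand that would account for the result.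

The compounds shown all keep an aryl group on the sulfonyl sulfur and the same remainder of the core, so they leave open what an aryl group carrying an amine or a carboxylic acid would give here, or a longer alkyl chain in place of the aryl group. With only one concentration tested, they also leave open whether the separation of compound 3 from compound 4 would persist as a difference in potency.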